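This account rests on a few compounds, and the source may have more. Where it says the series, first, only, none or still open, it means among the compounds named here.

Measured compounds:
compound 1 `COc1cc2c(Oc3ccc(NC(=O)N/N=C/c4ccc([N+](=O)[O-])cc4)cc3F)ccnc2cc1OCCCN1CCCC1` — 310 nM
compound 2 `COc1cc2c(Oc3ccc(NC(=O)N/N=C/c4ccc(Cl)cc4Cl)cc3F)ccnc2cc1OCCCN1CCCCC1` — 370 nM

Of the compounds shown here, two have so far been tested in a functional assay on HT-29 cells (Homo sapiens) for cytotoxicity, read by MTT assay, with a stated time of 72 h; a lower number here means a stronger inhibitor, a higher number a weaker inhibitor. Compound 1 gives 310 nM in this assay, and compound 2 gives 370 nM. The two numbers lie within the usual scatter of each other, so neither compound can be set apart from the other on this evidence.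

Compound 3 `COc1cc2c(Oc3ccc(NC(=O)N/N=C/c4ccncc4)cc3F)ccnc2cc1OCCCN1CCCCC1` has not yet been measured. It differs from compound 2 in one place: pyridin-4-yl in place of 2,4-dichlorophenyl on a carbon with a double bond to nitrogen. For the measured compounds named here, no measured pair in this set shows what such an exchange does in this assay, so the expectation rests on the measured values alone, with no guidance on direction. Compound 3 is expected to give about 600 nM in this assay, with a range from 200 nM to 2000 nM. This would mean an estimated step of a 1.6-fold higher number from compound 2 to compound 3 (0.21 log units; within the scatter), a small weakening that may well fall within the scatter.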

Compound 3, half-maximal inhibitory concentration: 940 nM
Compound 3: the middle estimate sits 1.6-fold (0.19 log units) below what was measured; the range from low to high includes it.
By their numbers in this assay, from the lowest: compounds 1 and 2 (each within the scatter of the next); then compound 3.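

Replacing 2,4-dichlorophenyl with pyridin-4-yl on a carbon with a double bond to nitrogen brings a 2.5-fold higher number from compound 2 to compound 3 (0.40 log units; beyond the scatter) in this assay. For the compounds shown here, this is the first exchange at this position that can be read, and it shows that the group held there can move the number, though only modestly. Going by these compounds alone, nothing measured so far explains the step.

The change removes a ring of carbon only with two chlorine atoms and brings in a ring with one nitrogen, so these compounds leave open whether losing the chlorine atoms or gaining the nitrogen matters more; a plain phenyl group or a 4-chlorophenyl group in the same place would help separate the two. From the compounds shown here alone, it also remains open whether the step would hold with another amine, such as morpholine, in place of the piperidine.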